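Hydroxy to methoxy on the 2-hydroxyphenyl group

The source may report more compounds than this note shows. Statements on the series, on what has been measured and on what is new or still open speak of the compounds shown alone.

In an ADME assay on HepG2 cells (Homo sapiens) for cytotoxicity, read by MTT assay, with a stated time of 48 h, tested at 1 uM (a higher number here means a stronger effect of the compound at the concentration tested, a lower number a weaker effect), compound 1 `O=c1cc(-c2cccc(O)c2)oc2cc(OCCCCCCCCN3CCCC3)ccc12` gives 19%, compound 2 `O=c1cc(-c2ccc(Cl)cc2)oc2cc(OCCCCCCCCN3CCCC3)ccc12` gives 6.39%, and compound 3 `O=c1cc(-c2ccccc2O)oc2cc(OCCCCCCCCN3CCCC3)ccc12` gives 5.92%. Compound 3 holds the lowest of the three numbers, but its gap to compound 2 is within the scatter; only compound 1 stands apart, with a number 13.1 percentage points lower from compound 1 to compound 3 (beyond the scatter) and a number 12.6 percentage points lower from compound 1 to compound 2 (beyond the scatter). Between the two low compounds the change is a number 0.5 percentage points lower from compound 2 to compound 3 (within the scatter).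

Compound 4 `COc1ccccc1-c1cc(=O)c2ccc(OCCCCCCCCN3CCCC3)cc2o1` carries methyl in place of hydrogen on an oxygen on an aromatic ring. Going by the values given here, no measured step replaces hydrogen by methyl on this oxygen. The steps that exchange the substituent on that phenyl ring, a number 13.1 percentage points lower from compound 1 to compound 3 (beyond the scatter) and a number 0.5 percentage points lower from compound 2 to compound 3 (within the scatter), move the read-out by little or by a modest amount, and adding one carbon to an existing hydroxy is a smaller structural change than either of those exchanges. The step of a number 1.1 percentage points higher from compound 3 to compound 4 (within the scatter) is therefore expected to stay within the scatter, with no clear direction. Compound 4 is estimated at 7%, with a range from 0% to 18%.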

Compound 4, a percentage reported as inhibition, at one concentration (the size of the read-out at that concentration, not a potency): 5.9%
Compound 4: the middle estimate sits 1.1 percentage points above what was measured; measured number inside the range.
By their numbers in this assay, from the lowest: compounds 4, 3 and 2 (each within the scatter of the next); then compound 1.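

Methyl on the oxygen of the 2-hydroxyphenyl group leaves the read-out in this assay in place (a number 0 percentage points lower from compound 3 to compound 4 (within the scatter)), so hydroxy and methoxy cannot be told apart at this position. The 2-methoxyphenyl compound also stays level with the 4-chlorophenyl compound (a number 0.5 percentage points lower from compound 2 to compound 4 (within the scatter)), while the exchange from the 3-hydroxyphenyl group keeps a modest gap (a number 13.1 percentage points lower from compound 1 to compound 4 (beyond the scatter)), which leaves compound 1 as the only one of the four that stands apart. Nothing at hand bears on why this change leaves the number in place.

Still open, going by these compounds, is whether a larger group on this oxygen, such as ethyl or a longer chain ending in an amine, would also leave the read-out in place. Also open, on these data alone, is whether methoxy in place of the hydroxy of compound 1 would keep its higher number.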